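The compounds below may be only part of what the source reports. "The series", "measured", "known", "first", "only" and "open" are said of these compounds alone.

Compound 1 `O=C(CCCCCCc1ccccc1)c1ncc(-c2ncccn2)o1` and compound 2 `O=C(CCCCCCc1ccccc1)c1ncc(C(=O)N2CCOCC2)o1` share a core and differ only in the group carried on the five-membered aromatic ring. In an assay (Rattus norvegicus) for inhibition of Fatty-acid amide hydrolase 1 (Homo sapiens) (on this read-out higher numbers stand for weaker inhibition and lower numbers for stronger inhibition), compound 1 gives 5.3 nM, and compound 2 gives 24 nM. Going by the values given here, compound 2 thus stands at the highest of the two numbers measured, with compound 1 giving the lower one; the one measured step, a 4.5-fold higher number from compound 1 to compound 2 (0.66 log units; beyond the scatter), already shows that exchanging the group on that aromatic carbon moves this assay by a modest amount. Compound 3 `O=C(CCCCCCc1ccccc1)c1ncc(I)o1` follows from compound 2 by iodo in place of (morpholin-4-yl)carbonyl on an aromatic carbon. Among the compounds with values here, the only step that bears on this change is the one from compound 1 to compound 2, which concerns the same position but a different pair of groups, so its size gives a scale rather than a direction. The account expects a modest rise, a 2.5-fold higher number from compound 2 to compound 3 (0.40 log units; beyond the scatter). Compound 3 is therefore estimated at 60 nM, within 15 nM to 250 nM.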

Compound 3, inhibition constant: 3 nM
The estimate for compound 3 lay 20-fold (1.30 log units) above the measured number; measured number below the stated range.
By their numbers in this assay, from the lowest: compounds 3 and 1 (each within the scatter of the next); then compound 2.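

Iodo in place of (morpholin-4-yl)carbonyl next to the ring oxygen gives an 8.0-fold lower number from compound 2 to compound 3 (0.90 log units; beyond the scatter), so a single iodine atom with no ring and no hydrogen-bond acceptors is enough at this position to reach the low numbers, and a ring-bearing group is not required there. Iodo and pyrimidin-2-yl cannot be told apart, as a 1.8-fold lower number from compound 1 to compound 3 (0.25 log units; within the scatter) shows, which leaves compound 2 as the only one of the three standing apart from the others. Nothing at hand accounts for this result.

The compounds shown leave open whether a smaller halogen such as chloro or bromo, or a bare hydrogen, would keep the number this low on the same carbon. They also leave open how a carboxylic acid or a simple amine would fare there.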